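Estimating Compound 4 from Three Measured Analogues

This account rests on a few compounds, and the source may have more. Where it says the series, first, only, none or still open, it means among the compounds named here.

Compound 1 `CCOC(=O)C(=O)NC1=C(C#N)C2C(N3CCCC3)CCCCN2C(=O)N1c1ccccc1` gives 91.5% in a functional assay on the whole organism (strain albino) for inhibition, with Rattus norvegicus as the target, read by paw edema, with stated times of 1 h and 3 h, at a dose of 20 mmol/kg by the intraperitoneal route; on this read-out higher numbers stand for a stronger effect at the one dose given and lower numbers for a weaker effect.
Compound 2 `N#CC1=C(/N=C/c2ccccc2)N(c2ccccc2)C(=O)N2CCCCC(N3CCCC3)C12` gives 84% in this assay.
Compound 3 `N#CC1=C(NCC(=O)N2CCCCC2)N(c2ccccc2)C(=O)N2CCCCC(N3CCCC3)C12` gives 53.5% in this assay.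

Compound 1 stands highest of the three numbers, with compound 2 nearest through a number 7.5 percentage points lower from compound 1 to compound 2 (within the scatter) and compound 3 furthest through a number 38 percentage points lower from compound 1 to compound 3 (beyond the scatter). Compound 4 `COc1ccc(/C=N/C2=C(C#N)C3C(N4CCCC4)CCCCN3C(=O)N2c2ccccc2)cc1` differs from compound 1 in one place: a group of 10 heavy atoms (8 carbon, 1 nitrogen, 1 oxygen; one six-membered aromatic ring of carbon only) in place of a group of 8 heavy atoms (4 carbon, 1 nitrogen, 3 oxygen; no ring), on a double-bonded ring carbon. Going by the values given here, the step that bears most on this change is the one to compound 2, a number 7.5 percentage points lower from compound 1 to compound 2 (within the scatter), which also exchanged the leaving group, on the same double-bonded ring carbon, for a group holding a six-membered aromatic ring of carbon only, and which stayed within the scatter. The two large falls, a number 38 percentage points lower from compound 1 to compound 3 (beyond the scatter) and a number 30.5 percentage points lower from compound 2 to compound 3 (beyond the scatter), both concern the group present in compound 3 and do not bear on compound 4. Among the compounds with values here, no measured step joins compound 2 to compound 4, so only their two values can be compared once compound 4 is read. Compound 4 is therefore expected to stay close to compound 1, with a step of a number 6.5 percentage points lower from compound 1 to compound 4 (within the scatter) that lies within the scatter. The estimated value of compound 4 is 85%, ranging from 70% to 95%.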

Compound 4, a percentage reported as inhibition, in the whole organism at one dose (the size of the read-out at that dose, not a potency): 75.3%
Beside the measured number, compound 4's estimate is 9.7 percentage points above it; the measured number falls inside the stated range.
By their numbers in this assay, from the lowest: compound 3; then compounds 4, 2 and 1 (each within the scatter of the next, the first and the last beyond it).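

In this assay, the group with a six-membered aromatic ring and a methoxy in place of ((ethoxycarbonyl)carbonyl)amino gives a number 16.2 percentage points lower from compound 1 to compound 4 (beyond the scatter) and so takes the value beyond the scatter, which the step to compound 2 had not done at this double-bonded ring carbon. Methoxy in place of hydrogen on an aromatic carbon gives a number 8.7 percentage points lower from compound 2 to compound 4 (within the scatter) and does not separate the two compounds. The group in compound 4 still keeps its distance from the piperidine-bearing group, with a number 21.8 percentage points higher from compound 3 to compound 4 (beyond the scatter) at the same carbon. Nothing at hand gives a reason for these steps.

The compounds shown leave open whether chloro or hydroxy in place of methoxy on the aromatic carbon would read differently. They also leave open how a free amine or a carboxylic acid would read on the double-bonded ring carbon.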